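Sulfone for Benzylsulfanyl on a Trimethoxy Core

A few compounds are considered here, and "the series" means these few. Any claim that something is new, unique, unknown or untested is made for them only; others in the source may bear on it.

Measured so far in a functional assay on DU-145 cells (Homo sapiens) for inhibition, read by trypan blue exclusion, with a stated time of 96 h; a lower number here means a stronger inhibitor of growth, a higher number a weaker inhibitor of growth:
compound 1 `O=C(/C(=C\c1c(O)cc(O)cc1O)SCc1ccc(Cl)c(Cl)c1)c1ccc(Cl)cc1` — 25000 nM
compound 2 `COc1cc(OC)c(/C=C(/SCc2ccc(Cl)c(Cl)c2)C(=O)c2ccc(Cl)cc2)c(OC)c1` — 10000 nM
compound 3 `O=C(/C(=C\c1c(O)cc(O)cc1O)S(=O)(=O)c1ccc(Br)cc1)c1ccc(Cl)cc1` — > 100000 nM

Of the compounds shown here, three have been measured in this assay. Compound 1 gives 25000 nM. Compound 2 gives the lowest of the two numbers, 10000 nM, a step beyond the scatter from compound 1. For compound 3 this assay reports only a limit, > 100000 nM, and not a number; this is the limit of > 100000 nM in this assay, at which 1 of the 3 values shown sits.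

Compound 1 and compound 3 differ in one place: (4-bromophenyl)sulfonyl in place of (3,4-dichlorobenzyl)sulfanyl on a double-bonded chain carbon bound to a carbonyl carbon and a double-bonded chain carbon. That change gave an at least 4.0-fold higher number from compound 1 to compound 3 (0.60 log units; beyond the scatter). How the core of compound 2 differs from the core of compound 1 is not broken down here.

Compound 4 `COc1cc(OC)c(/C=C(\C(=O)c2ccc(Cl)cc2)S(=O)(=O)c2ccc(Br)cc2)c(OC)c1` has not yet been measured in this assay. It differs from compound 2 by the same change: (4-bromophenyl)sulfonyl in place of (3,4-dichlorobenzyl)sulfanyl on a double-bonded chain carbon bound to a carbonyl carbon and a double-bonded chain carbon. Since this change has been seen only once among the measured compounds, the expectation for compound 4 rests on that single step. The step is expected to be a 5.0-fold higher number from compound 2 to compound 4 (0.70 log units; beyond the scatter), weakening rather than strengthening, because the same change from compound 1 gave an at least 4.0-fold higher number from compound 1 to compound 3 (0.60 log units; beyond the scatter). As compound 2 starts from a lower number than compound 1, there is some room before the limit of this assay is reached, but a limit is a real possibility. Compound 4 is therefore estimated at 50000 nM, expected between 15000 nM and 150000 nM.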

Compound 4, concentration for 50% growth inhibition: > 100000 nM
Compound 4: no number, only a limit; the forecaster's own chance of this, stated with the estimate: 40%; middle value at least 2.0-fold (0.30 log units) from the limit.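

In this assay compound 4 gives only a limit, > 100000 nM, and not a number. Placing (4-bromophenyl)sulfonyl on the double-bonded chain carbon in place of (3,4-dichlorobenzyl)sulfanyl gave an at least 10-fold higher number from compound 2 to compound 4 (1.00 log units; beyond the scatter), so on the second core the change again went toward weaker growth inhibition, and in these two pairs its direction carried from one core to the other: the same change on two cores in this assay, an at least 4.0-fold higher number (0.60 log units; beyond the scatter) from compound 1 to compound 3 and an at least 10-fold higher number (1.00 log units; beyond the scatter) from compound 2 to compound 4; the limit leaves it open whether they differ What this does not show is the true size of the step on either core, or whether the core alters that size, since compound 3 and compound 4 both end at a limit: the limit of > 100000 nM in this assay, at which 2 of the 4 values shown sit.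

The change replaces the sulfur-containing link and the aromatic group together, and the compounds shown leave open which of the two goes with the step; a (3,4-dichlorobenzyl)sulfonyl group or a (4-bromophenyl)sulfanyl group at the same place would pull the two apart. They also leave open whether a group of another kind at this place, such as an amine or a carboxylic acid, would give a measurable number on either core.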